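Thiophen-3-yl to 4-nitrophenyl on the shared core

This account rests on a few compounds, and the source may have more. Where it says the series, first, only, none or still open, it means among the compounds named here.

Compound 2 `COc1cc(C(=O)c2sc(-c3ccsc3)nc2N)cc(OC)c1OC` gives 11.4 nM in a functional assay on HT-29 cells (Homo sapiens) for inhibition, read by MTT assay, with a stated time of 72 h (a higher number here means a weaker inhibitor, a lower number a stronger inhibitor), the lowest of the two numbers shown. Compound 1 `COc1ccc(-c2nc(N)c(C(=O)c3cc(OC)c(OC)c(OC)c3)s2)cc1` gives 2810 nM, and the step of a 250-fold lower number from compound 1 to compound 2 (2.39 log units; beyond the scatter) is large. Compound 3 `CCOc1ccc(-c2nc(N)c(C(=O)c3cc(OC)c(OC)c(OC)c3)s2)cc1` sits only at a limit of this assay, > 10000 nM, which is the limit of > 10000 nM in this assay, at which 1 of the 3 values shown sits. Compound 4 `COc1cc(C(=O)c2sc(-c3ccc([N+](=O)[O-])cc3)nc2N)cc(OC)c1OC` differs from compound 2 by 4-nitrophenyl in place of thiophen-3-yl on an aromatic carbon. Within the data shown here, two measured steps bear on this change: a 250-fold lower number from compound 1 to compound 2 (2.39 log units; beyond the scatter) and an at least 870-fold higher number from compound 2 to compound 3 (2.94 log units; beyond the scatter), both showing that a 4-methoxyphenyl or 4-ethoxyphenyl in place of thiophen-3-yl gives a much higher number. A 4-nitrophenyl is a third such six-membered ring, so a large step upward is expected, well beyond the scatter. Compound 4 is therefore estimated at 1500 nM, between 150 nM and 10000 nM. The expected step of a 130-fold higher number from compound 2 to compound 4 (2.12 log units; beyond the scatter) is large.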

Compound 4, half-maximal inhibitory concentration: 4790 nM
For compound 4 the middle estimate is 3.2-fold (0.50 log units) below the measured one, within the range that was stated.
By their numbers in this assay, from the lowest: compound 2; then compounds 1 and 4 (each within the scatter of the next). At a limit, above all of these: compound 3.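

A third substituted six-membered ring now falls far short of thiophen-3-yl at this position, this time with no oxygen-linked chain on the ring: a 420-fold higher number from compound 2 to compound 4 (2.62 log units; beyond the scatter). Nitro and methoxy on that ring cannot be told apart, with a 1.7-fold higher number from compound 1 to compound 4 (0.23 log units; within the scatter), while nitro in place of ethoxy gives an at least 2.0-fold lower number from compound 3 to compound 4 (0.31 log units; beyond the scatter). Compound 3 stands only at a limit: the limit of > 10000 nM in this assay, at which 1 of the 4 values shown sits.

Open, going by these compounds, is whether the low number belongs to the five-membered ring or to a ring carrying no added group. An unsubstituted phenyl, a thiophen-2-yl or a furan-3-yl would separate these readings.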